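A few compounds are considered here, and "the series" means these few. Any claim that something is new, unique, unknown or untested is made for them only; others in the source may bear on it.

Compound 1 `Cc1cccc(Cn2cc(COc3ccc4c(=O)ccoc4c3)nn2)c1` gives 11700 nM in a functional assay on SW480 cells (Homo sapiens) for cytotoxicity, read by MTT assay, with a stated time of 48 h; on this read-out higher numbers stand for weaker inhibition and lower numbers for stronger inhibition. Compound 2 `Cc1ccc(Cn2cc(COc3ccc4c(=O)ccoc4c3)nn2)cc1` gives 10400 nM in this assay. Compound 3 `N#Cc1ccc(Cn2cc(COc3ccc4c(=O)ccoc4c3)nn2)cc1` gives only a limit of the assay, > 100000 nM.

Compound 2 stands lowest of the two plain numbers, but the step of a 1.1-fold lower number from compound 1 to compound 2 (0.05 log units; within the scatter) is within the scatter, so compound 1 and compound 2 cannot be told apart. Compound 4 `O=c1ccoc2cc(OCc3cn(Cc4ccc([N+](=O)[O-])cc4)nn3)ccc12` is not yet measured. It differs from compound 2 by nitro in place of methyl on an aromatic carbon. The closest measured step swaps the same methyl for a different group: an at least 9.6-fold higher number from compound 2 to compound 3 (0.98 log units; beyond the scatter), and the related step of an at least 8.5-fold higher number from compound 1 to compound 3 (0.93 log units; beyond the scatter) points the same way, both ending at the assay limit (the limit of > 100000 nM in this assay, at which 1 of the 3 values shown sits). For the measured compounds named here, only one such swap has been measured, so the expectation rests on a single comparison. Still, a step in the same direction, toward a weaker compound, is expected for a 6.7-fold higher number from compound 2 to compound 4 (0.83 log units; beyond the scatter). Compound 4 is therefore estimated to give 70000 nM in this assay, with a range from 20000 nM to 250000 nM, and a fair chance that the assay again returns only a limit.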

Compound 4, half-maximal inhibitory concentration: 19300 nM
Estimate against measurement, compound 4: 3.6-fold (0.56 log units) above; measured number below the stated range.
By their numbers in this assay, from the lowest: compounds 2, 1 and 4 (each within the scatter of the next). At a limit, above all of these: compound 3.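

The swap to 4-nitrophenyl gives a 1.9-fold higher number from compound 2 to compound 4 (0.27 log units; within the scatter) in this assay, and the comparison with the other methyl compound gives a 1.6-fold higher number from compound 1 to compound 4 (0.22 log units; within the scatter), so compound 4 cannot be told apart from either of them. The sharp rise seen with cyano is therefore not shared by every group placed here, as nitro in place of cyano gives an at least 5.1-fold lower number from compound 3 to compound 4 (0.71 log units; beyond the scatter). Compound 3 remains the only compound in this set whose result is a limit and not a number: the limit of > 100000 nM in this assay, at which 1 of the 4 values shown sits.

What separates cyano from nitro at this position stays unexplained, as no property of either group has been measured here. Going by these compounds, whether an amine, a carboxylic acid or a longer chain in the same place would track with nitro or with cyano also remains open.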